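The source may hold more compounds than are shown below. What is called first, only, known or untested is meant among the compounds shown, and "the series" means these compounds.

Compound 1 `Cc1ccc(Nc2ncc3c(n2)N(C)C(=O)N(c2cc(NC(=O)c4cccc(C(F)(F)F)c4)ccc2C)C3)cc1`: 8000 nM
Compound 2 `Cc1ccc(NC(=O)c2cccc(C(F)(F)F)c2)cc1N1Cc2cnc(OC3CCN(C(=O)OC(C)(C)C)CC3)nc2N(C)C1=O`: > 10000 nM
Compound 3 `Cc1ccc(Nc2ncc3c(n2)N(C)C(=O)N(c2cc(NC(=O)c4cccc(C(F)(F)F)c4)ccc2C)C3)cc1N(C)C`: > 10000 nM

In an ADME assay on BaF3 cells (Mus musculus) for antiproliferative activity, read by CellTiter-Glo and CCK-8 assay, with a stated time of 72 h (a higher number here means a weaker inhibitor of growth, a lower number a stronger inhibitor of growth), compound 1 gives 8000 nM. For compound 2 the value > 10000 nM is a limit of the assay, not a number. For compound 3 the value > 10000 nM is likewise a limit. For the measured compounds named here, compound 3 thus sits at the limit of > 10000 nM in this assay, at which 2 of the 3 values shown sit; its only comparison is the step of an at least 1.2-fold higher number from compound 1 to compound 3 (0.09 log units; that floor lies within the scatter), which is itself only a floor and lies within the scatter, so no ranking against compound 1 can be drawn from it.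

Compound 4 `Cc1ccc(NC(=O)c2cccc(C(F)(F)F)c2)cc1N1Cc2cnc(OC3CCNCC3)nc2N(C)C1=O` differs from compound 3 by (piperidin-4-yl)oxy in place of (3-(dimethylamino)-4-methylphenyl)amino on an aromatic carbon. Going by the values given here, no measured step covers this change; the one step on record, an at least 1.2-fold higher number from compound 1 to compound 3 (0.09 log units; that floor lies within the scatter), concerns another part of the molecule and is a floor. With compound 3 at a limit, the step of a number no higher from compound 3 to compound 4 (the limit leaves the size open) is expected to be small, with no change beyond the scatter, or a further weakening, more likely than a gain. Compound 4 is therefore estimated at 10000 nM, range 3000 nM to 30000 nM, with a fair chance that the assay again reports only a limit.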

Compound 4, concentration for 50% growth inhibition: > 10000 nM
Compound 4 gave a limit, no number; the forecaster's own chance of this, stated with the estimate: 55%; the middle value lies on the limit itself.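

Replacing the aromatic amine on the carbon between two ring nitrogen atoms with (piperidin-4-yl)oxy gives no readable gain in this assay: the step reads an at least 1.2-fold higher number from compound 1 to compound 4 (0.09 log units; that floor lies within the scatter), a floor that allows no ranking of the two compounds. Removing tert-butoxycarbonyl from the ring nitrogen also yields no number, and the steps to compound 4 from compound 2 and from compound 3 cannot be read. The series now gathers at one limit: the limit of > 10000 nM in this assay, at which 3 of the 4 values shown sit.

Only compound 1 has a numerical value, so the compounds shown do not establish how much this position contributes to growth inhibition. As far as these compounds go, it remains open whether a morpholine or a small methoxy group at this position, or a change elsewhere on the shared core, would give a value inside the range of the assay.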